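The compounds below may be only part of what the source reports. "The series", "measured", "known", "first", "only" and "open" are said of these compounds alone.

Compound 2, with the structure `Fc1ccnc(Nc2cc3[nH]c(-c4ccc(F)c(F)c4)nc3cn2)c1`, has been examined in a physicochemical assay for solubility, using the shake flask method, in simulated intestinal fluid, measured as kinetic solubility, with a stated time of 20 h, at pH 6.5; a higher number here means a more soluble compound, a lower number a less soluble compound. In this assay compound 2 gives >= 50000 nM, which is a limit of the assay rather than a number. Compound 1, with the structure `Fc1ccc(-c2nc3cnc(Nc4ccccn4)cc3[nH]2)cc1F`, is its nearest measured neighbour, differing from it by a single fluoro in place of hydrogen on an aromatic carbon. In this assay compound 1 gives >= 50000 nM, again a limit. The step between them, a step that the two limits leave unreadable from compound 1 to compound 2, has a size that cannot be read, since (the limit of >= 50000 nM in this assay, at which 2 of the 2 values shown sit).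

Compound 3, with the structure `O=C(O)c1ccc(Nc2cc3[nH]c(-c4ccc(F)c(F)c4)nc3cn2)nc1`, is the next compound to be measured. It differs from compound 2 in one place: 5-carboxypyridin-2-yl in place of 4-fluoropyridin-2-yl on a nitrogen on an aromatic ring. Going by the values given here, only this one measured step bears on the change, and its size is hidden by the two limits, so nothing can be read from it about how an exchange on that ring moves solubility. The expectation for compound 3 rests on where compound 2 stands. Compound 3 is expected to give 50000 nM, within a range from 20000 nM to 50000 nM. The expected step from compound 2 to compound 3 is a number no higher from compound 2 to compound 3 (the limit leaves the size open), with the limit most likely reached again.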

Compound 3, solubility: 9000 nM
Estimate against measurement, compound 3: 5.6-fold (0.74 log units) above, and the stated range ends above it.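

In this assay, 5-carboxypyridin-2-yl in place of 4-fluoropyridin-2-yl on a nitrogen on an aromatic ring gives an at least 5.5-fold lower number from compound 2 to compound 3 (0.74 log units; beyond the scatter), so a change at this place can move the read-out by more than the usual scatter, which the earlier pair could not show. A carboxy group taking the place of a hydrogen gives an at least 5.5-fold lower number from compound 1 to compound 3 (0.74 log units; beyond the scatter), so the same holds when the comparison starts from the unsubstituted pyridin-2-yl ring of compound 1. The step between compound 1 and compound 2 still cannot be read, and the two new steps give only a smallest possible size, because the values of compound 1 and compound 2 are limits of the assay: the limit of >= 50000 nM in this assay, at which 2 of the 3 values shown sit.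

The compounds shown leave open how much larger the two new steps really are, and whether the fall follows from the carboxy group itself or from the larger group as a whole. A methyl ester, a primary amide or an aminomethyl group on the same ring could begin to separate these possibilities.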